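This account rests on a few compounds, and the source may have more. Where it says the series, first, only, none or still open, it means among the compounds named here.

Measured compounds:
Compound 1 `CC1CCN(c2nc(-c3ccccc3)nc3ccccc23)CC1`: in a functional assay on the whole organism for inhibition, with Rattus norvegicus as the target, read by paw edema, with stated times of 4 days, 1 h and 2 h, at a dose of 100 mg/kg by the oral route (on this read-out higher numbers stand for more inhibition at the one dose given (going by the name of the read-out) and lower numbers for less inhibition), compound 1 gives 69%.
Compound 2 `c1ccc(-c2nc(N3CCC(c4ccccc4)CC3)c3ccccc3n2)cc1`: in this assay compound 2 gives 85.3%.
Compound 3 `CC1CCN(c2nc(-c3ccccc3)nc3ccc(Br)cc23)CC1`: in this assay compound 3 gives 57.8%.

Compound 3 stands lowest of the three numbers. Its nearest neighbour is compound 1, from which it is set apart by the step of a number 11.2 percentage points lower from compound 1 to compound 3 (beyond the scatter), and compound 2 stands furthest from it, with a reading well above that of compound 3.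

Compound 4 `Brc1ccc2nc(-c3ccccc3)nc(N3CCC(c4ccccc4)CC3)c2c1` differs from compound 3 in one place: phenyl in place of methyl on a saturated ring carbon. Going by the values given here, one measured step bears directly on this change, namely a number 16.3 percentage points higher from compound 1 to compound 2 (beyond the scatter), which is the same exchange at the same place on the saturated ring, made on a core that lacks the bromo group. That step was modest but beyond the scatter and pointed upward, so a step of about the same size and direction is expected here, namely a number 16.2 percentage points higher from compound 3 to compound 4 (beyond the scatter). Compound 4 is therefore expected to give about 74% in this assay, with a range from 60% to 86%.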

Compound 4, a percentage reported as inhibition, in the whole organism at one dose (the size of the read-out at that dose, not a potency): 57.6%
The estimate for compound 4 lay 16.4 percentage points above the measured number; measured number outside the range, below it.
By their numbers in this assay, from the lowest: compounds 4 and 3 (each within the scatter of the next); then compound 1; then compound 2.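

On the bromo core, phenyl in place of methyl on the saturated ring carbon gives no change that stands out from the scatter, with a number 0.2 percentage points lower from compound 3 to compound 4 (within the scatter), so the rise seen on the core without bromo does not carry over in this assay: the same change on two cores in this assay, a number 16.3 percentage points higher (beyond the scatter) from compound 1 to compound 2 and a number 0.2 percentage points lower (within the scatter) from compound 3 to compound 4, 16.5 percentage points apart, beyond the scatter of two such steps

The bromo group in turn weighs more heavily where phenyl sits on the saturated ring than where methyl does, with a number 27.7 percentage points lower from compound 2 to compound 4 (beyond the scatter): the same change on two cores in this assay, a number 11.2 percentage points lower (beyond the scatter) from compound 1 to compound 3 and a number 27.7 percentage points lower (beyond the scatter) from compound 2 to compound 4, 16.5 percentage points apart, beyond the scatter of two such steps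

Across these four compounds the two changes therefore do not add up, and what the phenyl does depends on what the aromatic carbon carries.

Going by these compounds, whether this dependence extends to an amine or a carboxylic acid on the saturated ring carbon, or to chloro or methoxy in place of bromo, stays open. On these data alone, each number is also a reading at a single dose, and how the compounds compare at other doses remains unknown.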